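The compounds below may be only part of what the source reports. "The series", "measured", "known", "first", "only" and "open" are said of these compounds alone.

The two measured compounds share one core and differ in the chain on that core and in the group on the benzyl arm. Compound 1 `Cc1c(Cc2cc(C(F)(F)F)cc(C(F)(F)F)c2)nc(SCc2ccc([N+](=O)[O-])cc2)[nH]c1=O` carries a nitro group on that arm. In an ADME assay on MT4 cells (Homo sapiens) for cytotoxicity, read by MTT assay (on this read-out lower numbers stand for higher toxicity in this test and higher numbers for lower toxicity in this test), compound 1 gives only a limit of the assay, > 248000 nM, and no number. Compound 2 `CCc1c(Cc2cc(C(F)(F)F)cc(C(F)(F)F)c2)nc(SCc2ccc(OC)cc2)[nH]c1=O` carries a methoxy group in the same place. In this assay compound 2 likewise reaches only a limit, > 249000 nM. Among the measured compounds shown here, compound 2 thus stands at a limit, and the one other value shown is a limit too, so no step between measured compounds can be told; what is known is the limit of > 248000 nM in this assay, at which 1 of the 2 values shown sits, and (the limit of > 249000 nM in this assay, at which 1 of the 2 values shown sits). Compound 3 `CCc1c(Cc2cc(C(F)(F)F)cc(C(F)(F)F)c2)nc(SCc2ccc([N+](=O)[O-])cc2)[nH]c1=O` differs from compound 2 by nitro in place of methoxy on an aromatic carbon. Because compound 1, which carries the same nitro group, also sits at a limit of > 248000 nM, the expected step is a number no higher from compound 2 to compound 3 (the limit leaves the size open), none beyond the scatter. Compound 3 is estimated at 249000 nM, within a range from 120000 nM to 500000 nM, most likely again reported only as a limit.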

Compound 3, half-maximal cytotoxic concentration: > 242000 nM
Compound 3: only a limit was reported (the forecaster's own chance of this, stated with the estimate: 85%); the middle value lies beyond the limit too.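

Among the compounds shown here, compound 3, like compound 1 and compound 2, gives only a limit in this assay, so no step from compound 3 to either of the others can be read. The compounds shown leave open whether nitro in place of methoxy, or methyl in place of hydrogen on the chain, changes the read-out in this assay at all.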